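The compounds below may be only part of what the source reports. "The series", "measured", "known", "first", "only" and "open" are said of these compounds alone.

Compound 1 `CO/N=C/C=C/c1ccccc1OC(=O)c1ccccc1`; compound 2 `O=C(/C=C/c1ccccc1O)NO`; compound 3 `CN1CCN(C(=O)ONC(=O)/C=C/c2ccccc2OC(=O)c2ccccc2)CC1`; compound 4 `COc1ccccc1/C=C/C(=O)NO`, not yet measured.

Three compounds carry a result in a functional assay on HCT-116 cells (Homo sapiens) for inhibition, read by ELISA, with a stated time of 24 h; a lower number here means a stronger inhibitor of growth, a higher number a weaker inhibitor of growth. Compound 2 gives 16800 nM in this assay. Compound 3 gives 40400 nM in this assay. For compound 1 this assay reports only a limit, > 100000 nM, which is the limit of > 100000 nM in this assay, at which 1 of the 3 values shown sits, and not a number. Of the two numbers shown, compound 2 holds the lowest; its nearest neighbour is compound 3, whose number lies higher by a step beyond the usual scatter.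

Compound 4 differs from compound 2 in a single place: methyl in place of hydrogen on an oxygen on an aromatic ring. Within the data shown here, no two measured compounds differ in only one place, so no measured step of this kind exists to lean on. The change is modest in size, and the hydroxamic acid and the rest of the shared core of compound 2 remain untouched.

Compound 4 is therefore expected to give about 22000 nM in this assay, with a range from 7000 nM to 70000 nM. The step of a 1.3-fold higher number from compound 2 to compound 4 (0.12 log units; within the scatter) that this estimate means is expected to be small, within or barely beyond the scatter, if anything towards a higher number.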

Compound 4, concentration for 50% growth inhibition: 15300 nM
Compound 4: middle estimate off by 1.4-fold (0.16 log units), on the high side; the range from low to high includes it.
By their numbers in this assay, from the lowest: compounds 4 and 2 (each within the scatter of the next); then compound 3. At a limit, above all of these: compound 1.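

Among these compounds, the step of a 1.1-fold lower number from compound 2 to compound 4 (0.04 log units; within the scatter) in this assay is the first measured change at a single place, and it puts a number on methyl in place of hydrogen on an oxygen on an aromatic ring. It shows that the hydrogen on this oxygen is not needed to keep the number in this assay at the level of compound 2: hydroxy and methoxy at this place cannot be told apart here, as the step lies within the scatter. No measurement shown here bears on why the two forms read alike, so the result stands without an explanation.

The compounds shown leave open how much more this oxygen can carry, as a single methyl says little about what an ethyl, a longer chain or a chain ending in an amine would do at the same place. They also leave open how far the number depends on the hydroxamic acid of the shared core, which a carboxylic acid in its place would test directly.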